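The compounds below may be only part of what the source reports. "The series", "measured", "known", "first", "only" and "open" are said of these compounds alone.

Of the compounds shown here, two built on a shared core have been tested in a functional assay on MDA-MB-231 cells (Homo sapiens) for antiproliferative activity, read by sulforhodamine B assay, with a stated time of 48 h; a lower number here means a stronger inhibitor, a higher number a weaker inhibitor. Going by the values given here, compound 1 `Cc1cc(NS(=O)(=O)c2ccc(N/C(S)=N\c3ccnc4cc(C(F)(F)F)ccc34)cc2)on1` gives 80300 nM, while compound 2 `O=S(=O)(Nc1nccs1)c1ccc(N/C(S)=N\c2ccnc3cc(C(F)(F)F)ccc23)cc1` gives 24400 nM, the lowest of the two numbers; the only measured change is a 3.3-fold lower number from compound 1 to compound 2 (0.52 log units; beyond the scatter). Compound 3 `O=S(=O)(Nc1ccccn1)c1ccc(N/C(S)=N\c2ccnc3cc(C(F)(F)F)ccc23)cc1` differs from compound 2 by pyridin-2-yl in place of 1,3-thiazol-2-yl on a sulfonamide nitrogen. Among the compounds with values here, no measured step swaps a five-membered ring for a six-membered one, so that one known change is the sole guide to the size of a ring swap here. The expected step is a 1.2-fold higher number from compound 2 to compound 3 (0.09 log units; within the scatter). The estimate for compound 3 is 30000 nM, within the range 10000 nM to 90000 nM.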

Compound 3, half-maximal inhibitory concentration: 49300 nM
The estimate for compound 3 lay 1.6-fold (0.22 log units) below the measured number, within the range that was stated.
By their numbers in this assay, from the lowest: compound 2; then compounds 3 and 1 (each within the scatter of the next).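

In this assay, pyridin-2-yl in place of 1,3-thiazol-2-yl on the sulfonamide nitrogen gives a 2.0-fold higher number from compound 2 to compound 3 (0.31 log units; beyond the scatter) and so shows that this ring swap can be told from scatter. Pyridin-2-yl in place of 3-methyl-1,2-oxazol-5-yl gives a 1.6-fold lower number from compound 1 to compound 3 (0.21 log units; within the scatter) and leaves those two groups unseparated, so only compound 2 stands clear of both others. Nothing available explains the difference between these rings.

All three groups are aromatic rings. From the compounds shown here alone, how a non-aromatic group, such as an acetyl or a short alkyl chain, would behave on this nitrogen remains open.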